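Swapping fluoro for methoxy on compound 2

The compounds below may be only part of what the source reports. "The series", "measured", "known", "first", "only" and "open" are said of these compounds alone.

In an ADME assay on Huh-7 cells (Homo sapiens) for cytotoxicity (on this read-out higher numbers stand for lower toxicity in this test and lower numbers for higher toxicity in this test), compound 1 `CC(C)CCc1cc(C2=NS(=O)(=O)c3cc(NS(C)(=O)=O)ccc3N2)c(O)c2ccccc12` gives > 100000 nM as a limit and not a number. Compound 2 `CC(C)CCc1c(F)c(C2=NS(=O)(=O)c3cc(NS(C)(=O)=O)ccc3N2)c(O)c2ccccc12` gives > 100000 nM as a limit too, so it stands with the limit of > 100000 nM in this assay, at which 2 of the 2 values shown sit, as its only mark. Within the data shown here, the one measured step is a step that the two limits leave unreadable from compound 1 to compound 2 and offers no size to lean on. Compound 3 `COc1c(C2=NS(=O)(=O)c3cc(NS(C)(=O)=O)ccc3N2)c(O)c2ccccc2c1CCC(C)C` brings methoxy in place of fluoro on an aromatic carbon as methoxy in place of fluoro on an aromatic carbon. The expected change is an at least 1.1-fold lower number from compound 2 to compound 3 (0.04 log units; that floor lies within the scatter) and no step beyond the usual scatter is expected. Compound 3 is estimated at 90000 nM with a range from 35000 nM to 200000 nM as expected bounds.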

Compound 3, half-maximal cytotoxic concentration: 120000 nM
The estimate for compound 3 lay 1.3-fold (0.12 log units) below the measured number, and the stated range covers the measured number.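

Among these compounds, compound 1 and compound 2 each give only a limit, not a number, so no step among them or to compound 3 can be read. The compounds shown leave open how much hydrogen, fluoro or methoxy at this place changes the half-maximal cytotoxic concentration.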